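Changing the amide substituent on a shared aminothiophene core

A few compounds are considered here, and "the series" means these few. Any claim that something is new, unique, unknown or untested is made for them only; others in the source may bear on it.

Measured so far:
compound 1 `Nc1sc(-c2ccc(Cl)cc2)c(-c2ccc(Cl)cc2)c1C(=O)N1CCCCC1=O` — 1820 nM
compound 2 `Nc1sc(-c2ccc(Cl)cc2)c(-c2ccc(Cl)cc2)c1C(=O)N1CCOCC1` — 1870 nM
compound 3 `CCCCNC(=O)c1c(N)sc(-c2ccc(Cl)cc2)c1-c1ccc(Cl)cc1` — 8170 nM

Three compounds share one core and differ only in the group attached to the carbonyl carbon. In a functional assay on A549 cells (Homo sapiens) for inhibition, read by sulforhodamine B assay, with a stated time of 72 h (on this read-out higher numbers stand for weaker inhibition and lower numbers for stronger inhibition), compound 1 gives 1820 nM, the lowest of the three numbers. The step of a 1.0-fold higher number from compound 1 to compound 2 (0.01 log units; within the scatter) lies within the scatter, so compounds 1 and 2 cannot be told apart. The step of a 4.5-fold higher number from compound 1 to compound 3 (0.65 log units; beyond the scatter) is beyond the scatter, as is a 4.4-fold higher number from compound 2 to compound 3 (0.64 log units; beyond the scatter), so compound 3 stands apart from both.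

Compound 4 `CN1CCN(C(=O)c2c(N)sc(-c3ccc(Cl)cc3)c2-c2ccc(Cl)cc2)CC1` has not been measured. It differs from compound 1 in one place: 4-methylpiperazin-1-yl in place of 2-oxopiperidin-1-yl on a carbonyl carbon. Going by the values given here, of the measured steps, the one from compound 1 to compound 2 is the nearest analogy, since there too one six-membered non-aromatic ring on the carbonyl carbon replaces another, and that step was within the scatter. The larger steps to compound 3 involve butylamino, not a ring, and bear less on this change. Compound 4 is therefore expected to lie close to compound 1, with a 1.1-fold higher number from compound 1 to compound 4 (0.04 log units; within the scatter) expected to fall within the scatter. The estimate for compound 4 in this assay is 2000 nM, with a range from 900 nM to 4500 nM.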

Compound 4, half-maximal inhibitory concentration: 590 nM
Beside the measured number, compound 4's estimate is 3.4-fold (0.53 log units) above it, and the stated range ends above it.
By their numbers in this assay, from the lowest: compound 4; then compounds 1 and 2 (each within the scatter of the next); then compound 3.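

Compound 4 shows that the identity of the six-membered ring on the carbonyl carbon can matter in this assay, as the ring change gives a step beyond the scatter both ways it can be read (a 3.1-fold lower number from compound 1 to compound 4 (0.49 log units; beyond the scatter); a 3.2-fold lower number from compound 2 to compound 4 (0.50 log units; beyond the scatter)), whereas the earlier ring-for-ring step gave no such separation. With butylamino as the starting point, the same ring produces a larger step (a 14-fold lower number from compound 3 to compound 4 (1.14 log units; beyond the scatter)), and compound 4 is the most potent of the four in this assay. No supporting data are available to account for this difference.

The compounds shown do not separate the contribution of the methyl group from that of the second ring nitrogen. Piperazin-1-yl, which lacks the methyl, and 4-ethylpiperazin-1-yl, which has a longer chain on that nitrogen, would address this directly.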